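The compounds below may be only part of what the source reports. "The series", "measured", "known", "first", "only" and "open" are said of these compounds alone.

Measured compounds in an ADME assay on MT4 cells (Homo sapiens) for cytotoxicity, read by spectrophotometry, with a stated time of 5 days; on this read-out lower numbers stand for higher toxicity in this test and higher numbers for lower toxicity in this test:
compound 1 `O=C1/C(=N\NC(=S)NO)c2cc(Cl)ccc2N1CN1CCN(c2ccccc2)CC1` gives 273000 nM
compound 2 `CCn1cc(C(=O)O)c(=O)c2cc(F)c(N3CCN(CN4C(=O)/C(=N\NC(=S)NO)c5cc(F)ccc54)CC3)cc21` gives 208000 nM
compound 3 `O=C1/C(=N\NC(=S)NO)c2cc(F)ccc2N1CN1CCN(c2ccccc2)CC1` gives 251000 nM

The three values lie within the scatter of one another, so no ordering among them is claimed. Compound 1 and compound 3 share a core and differ by chloro in place of fluoro on an aromatic carbon; this change made the step of a 1.1-fold higher number from compound 3 to compound 1 (0.04 log units; within the scatter). The core of compound 2 and the core of compound 3 are different, and that difference is not broken down here.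

Compound 4 `CCn1cc(C(=O)O)c(=O)c2cc(F)c(N3CCN(CN4C(=O)/C(=N\NC(=S)NO)c5cc(Cl)ccc54)CC3)cc21` is still to be measured in this assay. Within the data shown here, compound 4 differs from compound 2 by chloro in place of fluoro on an aromatic carbon, which is the same kind of change as the one from compound 3 to compound 1, at a place described in the same words. The expectation for compound 4 in this assay rests on compound 2 and its value 208000 nM and on the step of a 1.1-fold higher number from compound 3 to compound 1 (0.04 log units; within the scatter): the estimated step is a 1.1-fold higher number from compound 2 to compound 4 (0.04 log units; within the scatter), within the scatter. Compound 4 is therefore estimated at 230000 nM, with a range from 140000 nM to 380000 nM.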

Compound 4, half-maximal cytotoxic concentration: 186000 nM
Compound 4: the middle estimate sits 1.2-fold (0.09 log units) above what was measured; the measured number falls inside the stated range.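

In this assay, chloro in place of fluoro on an aromatic carbon gives a 1.1-fold lower number from compound 2 to compound 4 (0.05 log units; within the scatter), so on this core the step stays within the scatter. Set beside the earlier step on the other core, the two readings do not differ: the same change on two cores in this assay, a 1.1-fold higher number (0.04 log units; within the scatter) from compound 3 to compound 1 and a 1.1-fold lower number (0.05 log units; within the scatter) from compound 2 to compound 4, 1.2-fold (0.09 log units) apart, within the scatter of two such steps. This shows that the swap left the read-out unresolved from scatter on both cores, but it does not show a transferable effect of any size or direction, since neither step can be told from repeat noise, and two cores say nothing about other cores or other assays.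

The compounds shown carry only fluoro or chloro at this place, so the outcome with bromo, a methoxy group or an amine there remains open. No step shown lies beyond the scatter, so it also stays open which change at this place, if any, would move this read-out.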